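The source may report more compounds than this note shows. Statements on the series, on what has been measured and on what is new or still open speak of the compounds shown alone.

In a functional assay on MCF7 cells (Homo sapiens) for inhibition, read by MTT assay, with a stated time of 48 h, tested at 10 uM (on this read-out lower numbers stand for less inhibition of growth and higher numbers for more inhibition of growth at the one concentration tested), two compounds have been measured so far. Compound 1 (`Cc1cc(=O)c2c(O)cc(OCc3ccc(Br)cc3)c([C@H]3CCN(C)C[C@H]3O)c2o1`) gives 14%, and compound 2 (`Cc1cc(=O)c2c(O)c(CN3CCCC3CO)c(O)c([C@H]3CCN(C)C[C@H]3O)c2o1`) gives 22%. These two values lie within the usual scatter of each other, so compound 2 cannot be ranked against compound 1.

The next compound is compound 3 (`Cc1cc(=O)c2c(O)c(CN3CCCC3C(=O)O)c(O)c([C@H]3CCN(C)C[C@H]3O)c2o1`), which differs from compound 2 in one place: carboxy in place of hydroxymethyl on a saturated ring carbon. Carboxy stands in place of hydroxymethyl on a saturated ring carbon, next to the ring nitrogen. Going by the values given here, no measured pair shows the effect of this change, so the expectation starts from compound 2 at 22%. Only a small downward step, within the scatter, is expected. The estimated change is a number 5 percentage points lower from compound 2 to compound 3 (within the scatter). Compound 3 is expected to give 17%, with an estimated range from 5% to 30%.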

Compound 3, percent growth inhibition at one concentration: 21%
The estimate for compound 3 lay 4 percentage points below the measured number, within the range that was stated.
By their numbers in this assay, from the lowest: compounds 1, 3 and 2 (each within the scatter of the next).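

In this assay, going by these compounds alone, carboxy in place of hydroxymethyl on the saturated ring carbon next to the ring nitrogen gives a number 1 percentage points lower from compound 2 to compound 3 (within the scatter), the only step read so far at this position. The earlier compounds shown here offered no measured pair for this position, and this pair shows no difference between the two groups beyond the scatter at the one concentration tested. Nothing in hand offers an explanation for this result.

On these data alone, it remains open whether a primary amine, an amide or a longer chain such as hydroxyethyl on this ring carbon would give a step beyond the scatter. As far as these compounds go, it also remains open whether carboxy and hydroxymethyl would still not be told apart if the pyrrolidine ring were replaced by a piperidine ring.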